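A few compounds are considered here, and "the series" means these few. Any claim that something is new, unique, unknown or untested is made for them only; others in the source may bear on it.

Measured compounds:
compound 1 `O=C(COc1ccc2cc(/C=C3/SC(=O)NC3=O)ccc2c1)Nc1ccc(Br)cc1` — in an assay on isolated protein for inhibition of histone deacetylase 8 (Homo sapiens), with a stated time of 1 h (on this read-out higher numbers stand for weaker inhibition and lower numbers for stronger inhibition), compound 1 gives 16000 nM
compound 2 `Cc1cccc(NC(=O)COc2ccc3cc(/C=C4/SC(=O)NC4=O)ccc3c2)n1` — in this assay compound 2 gives 7500 nM
compound 3 `O=C(COc1ccc2cc(/C=C3/SC(=O)NC3=O)ccc2c1)Nc1ccc(Br)cc1F` — in this assay compound 3 gives > 50000 nM, which is a limit of the assay and not a number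

Compound 3 therefore stands at the weak end of the set shown, with only a limit to its name (the limit of > 50000 nM in this assay, at which 1 of the 3 values shown sits). Among the measured steps, an at least 3.1-fold higher number from compound 1 to compound 3 (0.49 log units; beyond the scatter) and an at least 6.6-fold higher number from compound 2 to compound 3 (0.82 log units; beyond the scatter) both run toward compound 3 and both are beyond the scatter, so the 4-bromo-2-fluorophenyl compound is the weakest of the three.

The step now followed is from compound 3 to compound 4 `O=C(COc1ccc2cc(/C=C3/SC(=O)NC3=O)ccc2c1)Nc1ccc(Br)c(Br)c1`, which differs as follows: 3,4-dibromophenyl in place of 4-bromo-2-fluorophenyl on an amide-type nitrogen. Compound 4 keeps the 4-bromo of compound 1 and adds a second bromine while giving up the fluorine whose addition went with an at least 3.1-fold higher number from compound 1 to compound 3 (0.49 log units; beyond the scatter). For the measured compounds named here, no measured step shows a second bromine on this ring, so the direction of the change is open. Compound 1 with 16000 nM is the nearest measured anchor. Compound 4 is expected to sit near it or somewhat weaker, with an estimated step of an at least 2.0-fold lower number from compound 3 to compound 4 (0.30 log units; that floor lies within the scatter) in this assay, amounting to a return toward a measurable number. Compound 4 is thus estimated at 25000 nM, within a range from 8000 nM to 80000 nM, with a real chance that only a limit is reported again.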

Compound 4, half-maximal inhibitory concentration: > 50000 nM
Compound 4 ended at the assay's limit; the forecaster's own chance of this, stated with the estimate: 40%; middle value at least 2.0-fold (0.30 log units) from the limit.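

Replacing hydrogen with bromo on an aromatic carbon goes with an at least 3.1-fold higher number from compound 1 to compound 4 (0.49 log units; beyond the scatter), so in this assay the second halogen on the 4-bromophenyl ring, whether the fluoro of compound 3 or the bromo of compound 4, comes with a loss from the level of compound 1, and neither of these compounds goes against that. The 3,4-dibromophenyl group also compares poorly with the 6-methylpyridin-2-yl group on the amide-type nitrogen, with an at least 6.6-fold higher number from compound 2 to compound 4 (0.82 log units; beyond the scatter), a floor of the same size as the one already seen for the 4-bromo-2-fluorophenyl group. The step between compound 3 and compound 4 cannot be read, as both values are limits of the assay: the limit of > 50000 nM in this assay, at which 2 of the 4 values shown sit.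

How far compound 3 and compound 4 lie past that limit remains unknown, so the compounds shown cannot tell whether fluoro and bromo differ in their effect here. From the compounds shown here alone, it also stays open whether the loss is specific to a second halogen or would follow from any added group, such as a methoxy, an amine or a carboxylic acid on the same phenyl ring.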